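Removing a Fluoro Group from a Compound Without Measured Activity

The source may hold more compounds than are shown below. What is called first, only, known or untested is meant among the compounds shown, and "the series" means these compounds.

compound 1 `O=C(CNC(=O)c1nn(-c2ccc(F)cc2)c(=O)c2ccccc12)Nc1nc2ccccc2s1`: > 25000 nM
compound 2 `O=C(CSc1nc2c(c(=O)n1-c1ccccc1)SCC2)Nc1nc(-c2ccccc2)cs1`: 350 nM
compound 3 `O=C(CSc1nc2c(c(=O)n1-c1ccccc1)SCC2)Nc1ccc(-c2ccoc2)cn1`: 1.5 nM

Of the compounds shown here, three have been measured in an assay on L cells for inhibition of Protein-serine O-palmitoleoyltransferase porcupine (Mus musculus), read by reporter gene assay, with a stated time of 24 h; on this read-out lower numbers stand for an effect already at smaller amounts and higher numbers for an effect only at larger amounts of compound. In this assay compound 1 gives > 25000 nM, which is a limit of the assay and not a number. Compound 1 thus stands at the limit of > 25000 nM in this assay, at which 1 of the 3 values shown sits. Compound 2, built on a different core, gives 350 nM in this assay. Compound 3, which shares that second core, gives 1.5 nM in this assay. Within the data shown here, no steps between these compounds are given, so their values are only reported side by side.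

Compound 4 `O=C(CNC(=O)c1nn(-c2ccccc2)c(=O)c2ccccc12)Nc1nc2ccccc2s1` keeps the core of compound 1 and differs from it in one place: hydrogen in place of fluoro on an aromatic carbon. Because compound 1 shows only (the limit of > 25000 nM in this assay, at which 1 of the 3 values shown sits), the size of the step to compound 4 cannot be read from a measured number. Compound 4 is expected to remain near the limit, with the step from compound 1 to compound 4 estimated at a step that the limit leaves unreadable from compound 1 to compound 4. The estimate for compound 4 in this assay is 30000 nM, with a range from 8000 nM to 100000 nM.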

Compound 4, half-maximal effective concentration: 2600 nM
Beside the measured number, compound 4's estimate is 12-fold (1.06 log units) above it; measured number outside the range, below it.
By their numbers in this assay, from the lowest: compound 3; then compound 2; then compound 4. At a limit, above all of these: compound 1.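

In this assay, hydrogen in place of fluoro on an aromatic carbon, para to a large group, gives an at least 9.6-fold lower number from compound 1 to compound 4 (0.98 log units; beyond the scatter). This single-atom change therefore matters at this position, and the core of compound 1 gains a measured value with the plain phenyl group of compound 4. Compound 1 sits at a limit of the assay and not at a number, so the step gives only a lower bound on the true size of the change: the limit of > 25000 nM in this assay, at which 1 of the 4 values shown sits.

The compounds shown do not reveal how other groups at this ring position, such as chloro, methoxy or an amine, would compare with hydrogen and fluoro. They also leave open whether adding a fluoro group at this position would have a similar effect on the core shared by compound 2 and compound 3.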